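The source may hold more compounds than are shown below. What is called first, only, known or untested is meant among the compounds shown, and "the series" means these compounds.

Among the measured compounds shown here, compound 2, `COc1cc2ncnc(-n3nc(-c4cccnc4)nc3N)c2cc1OC`, is one of only two compounds measured so far in a physicochemical assay for solubility, in phosphate buffer, with a stated time of 18 h, at pH 7.4; a higher number here means a more soluble compound, a lower number a less soluble compound. In this assay compound 2 gives 27000 nM. The other measured compound, compound 1, `COc1ccc2ncnc(-n3nc(-c4ccccn4)nc3N)c2c1`, gives 7000 nM in this assay, so compound 2 shows the higher number of the two, and the gap between them lies beyond the usual scatter. Compound 3, `COc1cc2ncnc(-n3nc(-c4ccc(Cl)cc4)nc3N)c2cc1OC`, has not yet been measured in this assay. It differs from compound 2 in one place: 4-chlorophenyl in place of pyridin-3-yl on an aromatic carbon. For the measured compounds named here, no step between two measured compounds matches this change, so nothing measured here shows its size directly. Because compound 2 gives 27000 nM, compound 3 is expected to give a lower number, with an estimated step of a 4.5-fold lower number from compound 2 to compound 3 (0.65 log units; beyond the scatter), a step somewhat beyond the scatter. Compound 3 is therefore expected to give about 6000 nM in this assay, with a likely range from 1500 nM to 20000 nM.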

Compound 3, solubility: 1000 nM
The estimate for compound 3 lay 6.0-fold (0.78 log units) above the measured number; measured number outside the range, below it.
By their numbers in this assay, from the lowest: compound 3; then compound 1; then compound 2.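

In this assay, putting 4-chlorophenyl in place of pyridin-3-yl on this aromatic carbon gives a 27-fold lower number from compound 2 to compound 3 (1.43 log units; beyond the scatter), a large step. This is the first pair shown that differs in only one place, so it shows that this position alone can move the number strongly while the rest of compound 2 stays the same. No measurement shown here accounts for the size of this drop.

The change removes the ring nitrogen and adds a chlorine at once, so the compounds shown cannot tell the two apart; plain phenyl would give the missing middle step. Also open, as far as these compounds go, is whether a ring carrying an amine or a carboxylic acid at this position would give a number above that of compound 2.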